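Working notes: changing the amide substituent of compound 3

The compounds below may be only part of what the source reports. "The series", "measured", "known", "first", "only" and "open" are said of these compounds alone.

Values so far in a functional assay on QGY cells (Homo sapiens) for cytotoxicity, read by MTT assay, with a stated time of 48 h (a lower number here means a stronger inhibitor, a higher number a weaker inhibitor), are as follows.
- compound 1 `CCOC(=O)[C@@]1(C(=O)NCc2ccc(C)cc2)C[C@H]1c1cc(OC)c(OC)c(OC)c1` gives 26400 nM
- compound 2 `COc1cc([C@H]2C[C@]2(CO)C(=O)NCc2ccc(C)cc2)cc(OC)c1OC` gives 56100 nM
- compound 3 `COc1cc([C@@H]2C[C@@]2(CO)C(=O)NCc2ccc(C)cc2)cc(OC)c1OC` gives 58700 nM

Compound 3 sits at the high end of these numbers, level within the scatter with its mirror image and clearly above only the ethoxycarbonyl analogue. The two measured gaps are (a 1.0-fold higher number from compound 2 to compound 3 (0.02 log units; within the scatter)) and (a 2.2-fold higher number from compound 1 to compound 3 (0.35 log units; beyond the scatter)). Compound 4 `COc1cc([C@@H]2C[C@@]2(CO)C(=O)Nc2ccccc2Cl)cc(OC)c1OC` carries 2-chlorophenyl in place of 4-methylbenzyl on an amide-type nitrogen. Neither measured step bears directly on this change, as all measured compounds keep 4-methylbenzyl. Within the data shown here, they show only that changes elsewhere have moved the number modestly or not at all. Taking compound 3 at 58700 nM as the anchor, no shift beyond the scatter is expected in this assay, with no direction favoured, and the range is kept wide. The estimated step is (a 1.2-fold lower number from compound 3 to compound 4 (0.07 log units; within the scatter)). Compound 4 is expected at 50000 nM (estimated range 18000 nM to 130000 nM).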

Compound 4, half-maximal inhibitory concentration: 24500 nM
Beside the measured number, compound 4's estimate is 2.0-fold (0.31 log units) above it; low and high end bracket the measured number.
By their numbers in this assay, from the lowest: compounds 4 and 1 (each within the scatter of the next); then compounds 2 and 3 (each within the scatter of the next).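

The amide nitrogen is a position where the number responds in this assay: 2-chlorophenyl in place of 4-methylbenzyl gives a step beyond the scatter, though a modest one (a 2.4-fold lower number from compound 3 to compound 4 (0.38 log units; beyond the scatter)). All earlier compounds kept 4-methylbenzyl, so they could not show that this substituent affects the number, and the direction here is towards a stronger inhibitor. Nothing available accounts for this step, as the only supporting fact concerns configuration within the 4-methylbenzyl pair.

The swap alters the group in more than one way, so the compounds shown leave open whether the step follows from the chlorine, the loss of the methyl or the aryl group sitting directly on the nitrogen. A 2-chlorobenzyl or plain phenyl group at this position would help separate these readings, and the mirror image of compound 4 would show whether configuration stays without consequence with this substituent.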